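The compounds below may be only part of what the source reports. "The series", "measured", "known", "first", "only" and "open" are said of these compounds alone.

Compound 2, with the structure `C=CCn1c(=O)n([C@H]2CO[C@@H](CO)C2)c2nc(N)nc(O)c21`, is one of two measured compounds in this series. In a functional assay on the whole organism with Mus musculus as the target (on this read-out higher numbers stand for larger maximal responses and lower numbers for smaller maximal responses), compound 2 gives 16%. Its nearest measured neighbour is compound 1, with the structure `C=CCn1c(=O)n(CCCCO)c2nc(N)nc(O)c21`; in this assay compound 1 gives 16%. Among the measured compounds shown here, the one measured step, no change at the digits printed from compound 1 to compound 2 (within the scatter), shows that exchanging the open chain for the ring left the maximal response where it was.

Compound 3, with the structure `C=CCn1c(=O)n(CCCC)c2nc(N)nc(O)c21`, has not yet been measured in this assay. It differs from compound 2 in one place: a group of 4 heavy atoms (4 carbon; no ring) in place of a group of 7 heavy atoms (5 carbon, 2 oxygen; one five-membered non-aromatic ring with 1 hetero atom), on an aromatic nitrogen.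

For the measured compounds named here, no measured step covers this kind of exchange, in which both oxygen atoms leave and a butyl group enters. Going by the values given here, the only step available, from compound 1 to compound 2, kept the oxygen count and gave no change beyond the scatter, so it offers little guidance on what removing the oxygen atoms does. With nothing pointing either way, the expected step of no change at the digits printed from compound 2 to compound 3 (within the scatter) is none beyond the scatter, but with wide uncertainty. Compound 3 is therefore expected to give about 16%, estimated to lie between 4% and 40%.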

Compound 3, largest response reached (reported as maximal response), in percent of the reference or control that the assay uses: 36%
Compound 3: the middle estimate sits 20 percentage points below what was measured, within the range that was stated.
By their numbers in this assay, from the lowest: compounds 1 and 2 (each within the scatter of the next); then compound 3.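

Replacing hydroxy with hydrogen, four bonds along the chain from an aromatic nitrogen, gives a number 20 percentage points higher from compound 1 to compound 3 (beyond the scatter) in this assay, so this single change on the saturated chain is enough to move the maximal response at this position. The larger exchange of the oxygen-bearing ring for a butyl group gives a number 20 percentage points higher from compound 2 to compound 3 (beyond the scatter), which shows that the response at this aromatic nitrogen can change even though the open chain of compound 1 and the ring of compound 2 stand level at the digits printed. Among these three compounds, the two that stand level both carry a hydroxy group and compound 3, the only one with the higher response, carries none, although no measurement here explains this difference.

Three compounds cannot show whether the hydroxy group alone accounts for the difference in every setting, and the step from compound 2 to compound 3 changes the ring, its oxygen and the hydroxy group all at once. From the compounds shown here alone, it also remains open how the maximal response would follow a longer chain such as hexyl, or an amine at the place of the hydroxy group.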